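A few compounds are considered here, and "the series" means these few. Any claim that something is new, unique, unknown or untested is made for them only; others in the source may bear on it.

Measured compounds in a functional assay on MCF7 cells (Homo sapiens) for cytotoxicity, read by MTT assay, with a stated time of 72 h; on this read-out higher numbers stand for weaker inhibition and lower numbers for stronger inhibition:
compound 1 `O=C(Nc1ccc(Oc2ccnc3[nH]ccc23)cc1)c1nn(-c2ccc(Br)cc2)ccc1=O` gives 7890 nM
compound 2 `O=C(Nc1ccc(Oc2ccnc3[nH]ccc23)c(F)c1)c1nn(-c2ccccc2)ccc1=O` gives 34900 nM
compound 3 `Cn1ccc2c(Oc3ccc(NC(=O)c4nn(-c5ccc(Br)cc5)ccc4=O)cc3)ccnc21` gives 16300 nM

Within this set compound 3 sits second highest of the three numbers. Its nearest neighbour is compound 1, from which it differs only by methyl in place of hydrogen on an aromatic nitrogen, and that step, a 2.1-fold higher number from compound 1 to compound 3 (0.32 log units; beyond the scatter), is modest but beyond the scatter. For the measured compounds named here, compound 2 differs from compound 1 in two places at once, so no single step is assigned to that pair; its number is the highest of the three.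

Compound 4 `Cn1ccc2c(Oc3ccc(NC(=O)c4nn(-c5ccc(Cl)c(C(F)(F)F)c5)ccc4=O)cc3)ccnc21` has not yet been measured. It differs from compound 3 in one place: 4-chloro-3-(trifluoromethyl)phenyl in place of 4-bromophenyl on an aromatic nitrogen. Going by the values given here, none of the measured steps touches the aryl group on this aromatic nitrogen; the only characterised step concerns the methyl on the other aromatic nitrogen, and the pair of compound 1 and compound 2 confounds two changes. Among the compounds with values here, there is therefore no precedent for this replacement, and the expectation rests on the absence of evidence rather than on a trend.

For compound 4 the expected step in this assay is a 2.3-fold lower number from compound 3 to compound 4 (0.37 log units; beyond the scatter), a modest change of uncertain direction that may well lie within the scatter. Compound 4 is thus estimated at 7000 nM, with a range from 2000 nM to 25000 nM.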

Compound 4, half-maximal inhibitory concentration: 15200 nM
Compound 4: the middle estimate sits 2.2-fold (0.34 log units) below what was measured; low and high end bracket the measured number.
By their numbers in this assay, from the lowest: compounds 1, 4 and 3 (each within the scatter of the next, the first and the last beyond it); then compound 2.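

In this assay, for the compounds shown here, the only single-place step at the aryl group on this aromatic nitrogen is a 1.1-fold lower number from compound 3 to compound 4 (0.03 log units; within the scatter). The exchange therefore leaves the number unchanged within the scatter, even though the entering 4-chloro-3-(trifluoromethyl)phenyl has 11 heavy atoms against 7 in the leaving 4-bromophenyl, so this one pair shows that this position can take a substantial change of halogen and added trifluoromethyl without a readable shift in cytotoxicity. No measured evidence is available that bears on why the two aryl groups read alike.

Going by these compounds alone, still open is whether the same exchange stays as flat with hydrogen in place of the methyl on the other aromatic nitrogen, the form carried by compound 1, since the single step at this aryl position comes from the methylated compounds alone. Equally open, from the compounds shown here alone, is whether this position stays flat for aryl groups of a different kind, such as a phenyl carrying an amine or a carboxylic acid, as both groups compared here bear only halogen or trifluoromethyl.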